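The source may hold more compounds than are shown below. What is called first, only, known or untested is meant among the compounds shown, and "the series" means these compounds.

Measured compounds:
Compound 1 `N#CC1=C(N)Oc2c(c3nc4ccccc4nc3c3ccccc23)C12C(=O)N(Cc1cnnn1-c1ccc(Cl)cc1)c1ccccc12` gives > 50000 nM in an ADME assay on L02 cells (Homo sapiens) for antiproliferative activity, read by MTT assay, with a stated time of 48 h (on this read-out lower numbers stand for stronger inhibition and higher numbers for weaker inhibition), a limit of the assay.
Compound 2 `N#CC1=C(N)Oc2c(c3nc4ccccc4nc3c3ccccc23)C12C(=O)N(Cc1cnnn1-c1ccc(Br)cc1)c1ccccc12` gives > 50000 nM in this assay, a limit of the assay.
Compound 3 `N#CC1=C(N)Oc2c(c3nc4ccccc4nc3c3ccccc23)C12C(=O)N(Cc1cnnn1-c1cccc(Br)c1)c1ccccc12` gives > 50000 nM in this assay, a limit of the assay.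

Compound 3 therefore stands at the upper limit of this assay, and no number is known for it. The two other compounds sit at the same limit, so that the limit of > 50000 nM in this assay, at which 3 of the 3 values shown sit, describes the whole picture so far. The steps among the measured compounds are a step that the two limits leave unreadable from compound 1 to compound 2, a step that the two limits leave unreadable from compound 1 to compound 3 and a step that the two limits leave unreadable from compound 2 to compound 3; none of them can be read, and none gives a size or a direction.

Compound 4 `N#CC1=C(N)Oc2c(c3nc4ccccc4nc3c3ccccc23)C12C(=O)N(Cc1cnnn1-c1cc(Cl)ccc1Cl)c1ccccc12` differs from compound 3 as follows: 2,5-dichlorophenyl in place of 3-bromophenyl on an aromatic nitrogen. The three measured steps bear on this change only in that they all concern an exchange of the aryl group on the same aromatic nitrogen, and all of them left the read-out at the limit. There is thus no basis for expecting a readable step in this assay in either direction. Within the data shown here, compound 4 is expected to remain at the limit, so that a step that the limit leaves unreadable from compound 3 to compound 4 is estimated to be no step that can be read. For compound 4 the estimate in this assay is 80000 nM, with a range from 30000 nM to 250000 nM.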

Compound 4, half-maximal inhibitory concentration: > 50000 nM
Compound 4: no number, only a limit; the forecaster's own chance of this, stated with the estimate: 85%; the middle value is on the limit's open side.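

In this assay compound 4 gives > 50000 nM, a limit of the assay and not a number. Its steps from compound 1, compound 2 and compound 3 therefore cannot be read. The compounds shown leave open where each one truly lies and whether exchanging the aryl group on the aromatic nitrogen changes the read-out at all: the limit of > 50000 nM in this assay, at which 4 of the 4 values shown sit.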